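The source may report more compounds than this note shows. Statements on the series, on what has been measured and on what is new or still open speak of the compounds shown alone.

Measured compounds:
compound 1 `Nc1ncc(Cl)nc1C(=O)Nc1ccccn1` — 11 nM
compound 2 `CNc1ncc(Cl)nc1C(=O)Nc1ccccn1` — 145 nM

In an assay on Ltk cells for inhibition of metabotropic glutamate receptor 5 (Homo sapiens), read by fluorescence (a higher number here means a weaker inhibitor, a lower number a stronger inhibitor), compound 1 gives the lowest of the two numbers shown, with compound 2 the nearest. Within the data shown here, the single measured step, a 13-fold higher number from compound 1 to compound 2 (1.12 log units; beyond the scatter), is methyl in place of hydrogen on a nitrogen on an aromatic ring. Compound 3 `Cc1cccc(NC(=O)c2nc(Cl)cnc2N)n1` differs from compound 1 by methyl in place of hydrogen on an aromatic carbon, on an aromatic carbon of a six-membered aromatic ring with 1 nitrogen, next to the ring nitrogen. Among the measured compounds shown here, no measured step covers a methyl at this site; the one step known concerns another place and is not taken to bear on it. A step within the scatter in this assay is therefore expected, as a 1.4-fold higher number from compound 1 to compound 3 (0.13 log units; within the scatter). Compound 3 is estimated at 15 nM, within 5 nM to 60 nM.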

Compound 3, half-maximal inhibitory concentration: 5 nM
Compound 3: the middle estimate sits 3.0-fold (0.48 log units) above what was measured; low and high end bracket the measured number.
By their numbers in this assay, from the lowest: compound 3; then compound 1; then compound 2.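

In this assay, methyl in place of hydrogen on an aromatic carbon, next to the ring nitrogen, moves the number down, not up (a 2.2-fold lower number from compound 1 to compound 3 (0.34 log units; beyond the scatter)), a modest step just beyond the scatter. Set against the large step the other way at the ring amine nitrogen (a 13-fold higher number from compound 1 to compound 2 (1.12 log units; beyond the scatter)), this shows that the direction of a methyl step on this series depends on the site. No measurement here accounts for this gain.

Going by these compounds, whether ethyl, methoxy or chlorine at this carbon would give a lower number remains open. On these data alone, the effect of methyl on the other carbons of this ring is also open.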